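From 4-methylphenyl to phenethyl on the carbonyl carbon

The source may hold more compounds than are shown below. What is called first, only, known or untested is meant among the compounds shown, and "the series" means these compounds.

Compound 1 (`CC1=NN(C(=O)CCl)C(c2cc(Br)ccc2O)C1`) gives 16300 nM
Compound 2 (`CC1=NN(C(=O)c2ccc(C)cc2)C(c2cc(Br)ccc2O)C1`) gives 23200 nM

Within the data shown here, the only measured step (a 1.4-fold higher number from compound 1 to compound 2 (0.15 log units; within the scatter)) leaves compound 2 level with compound 1 in a functional assay on HepG2 cells (Homo sapiens) for cytotoxicity, read by MTT assay, with a stated time of 48 h (a higher number here means a weaker inhibitor, a lower number a stronger inhibitor), and gives neither a clear edge. Compound 3 (`CC1=NN(C(=O)CCc2ccccc2)C(c2cc(Br)ccc2O)C1`) carries phenethyl in place of 4-methylphenyl on a carbonyl carbon. The measured step changed the group on that same carbonyl carbon and stayed small, so no change beyond the scatter is expected in this assay for this swap either. The expected step is a 1.2-fold lower number from compound 2 to compound 3 (0.06 log units; within the scatter) and remains an estimate. Compound 3 is expected at 20000 nM (9000 nM to 45000 nM).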

Compound 3, half-maximal inhibitory concentration: 17900 nM
The estimate for compound 3 lay 1.1-fold (0.05 log units) above the measured number; measured number inside the range.
By their numbers in this assay, from the lowest: compounds 1, 3 and 2 (each within the scatter of the next).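

In this assay, phenethyl in place of 4-methylphenyl on the carbonyl carbon gives a 1.3-fold lower number from compound 2 to compound 3 (0.11 log units; within the scatter), so putting a chain between this ring and the carbonyl carbon brings no readable change. Benzyl in place of chloro on the saturated chain carbon gives a 1.1-fold higher number from compound 1 to compound 3 (0.04 log units; within the scatter), which places all three groups at this position level with one another. Nothing available explains why they read alike.

Going by these compounds, it remains open whether any group on this carbonyl carbon can move the number beyond the scatter. An amine or a carboxylic acid at the end of the chain would test this.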